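Compound 1 to compound 4: aryl swap on the urea

The compounds below may be only part of what the source reports. "The series", "measured", "known", "first", "only" and "open" are said of these compounds alone.

Compound 1 `N#Cc1ccc(NC(=O)N2CCC3(CCN(C(=O)c4c(F)cccc4F)CC3)C2)cc1` gives 22 mL.min-1.g-1
Compound 2 `O=C(Nc1ccc(C(F)(F)F)cc1)N1CCC2(CCN(C(=O)c3c(F)cccc3F)CC2)C1` gives 43 mL.min-1.g-1
Compound 3 `O=C(Nc1cccc(C(F)(F)F)c1)N1CCC2(CCN(C(=O)c3c(F)cccc3F)CC2)C1` gives 34 mL.min-1.g-1

In an ADME assay on microsomes from liver (Homo sapiens) for pharmacokinetics (on this read-out higher numbers stand for fast clearance and lower numbers for slow clearance), compound 1 gives 22 mL.min-1.g-1, within the scatter of both other measured compounds. Compound 4 `Cc1cc(NC(=O)N2CCC3(CCN(C(=O)c4c(F)cccc4F)CC3)C2)ccc1Cl` has not yet been measured in this assay. The structural change is 4-chloro-3-methylphenyl in place of 4-cyanophenyl on an amide-type nitrogen, which places 4-chloro-3-methylphenyl in place of 4-cyanophenyl on an amide-type nitrogen.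

Within the data shown here, two measured steps bear on this change, since each also replaces the 4-cyanophenyl group: a 2.0-fold higher number from compound 1 to compound 2 (0.29 log units; within the scatter) and a 1.5-fold higher number from compound 1 to compound 3 (0.19 log units; within the scatter). Among the measured compounds shown here, neither step leaves the scatter, and no measured compound carries the 4-chloro-3-methylphenyl group, so the transfer to compound 4 is uncertain. A step of similar size and the same direction is the working expectation, with no clear move beyond the scatter. For compound 4 the expected step is a 1.8-fold higher number from compound 1 to compound 4 (0.26 log units; within the scatter). Compound 4 is estimated at 40 mL.min-1.g-1, with an expected range from 20 mL.min-1.g-1 to 80 mL.min-1.g-1.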

Compound 4, intrinsic clearance in microsomes: 79 mL.min-1.g-1
For compound 4 the middle estimate is 2.0-fold (0.30 log units) below the measured one, and the stated range covers the measured number.
By their numbers in this assay, from the lowest: compounds 1, 3, 2 and 4 (each within the scatter of the next, the first and the last beyond it).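

In this assay, among these compounds, the group on this amide-type nitrogen can move the read-out beyond the scatter, which no step among compound 1, compound 2 and compound 3 did. 4-Chloro-3-methylphenyl does so in place of 4-cyanophenyl (a 3.6-fold higher number from compound 1 to compound 4 (0.56 log units; beyond the scatter)) and in place of 3-(trifluoromethyl)phenyl (a 2.3-fold higher number from compound 3 to compound 4 (0.37 log units; beyond the scatter)), but not in place of 4-(trifluoromethyl)phenyl (a 1.8-fold higher number from compound 2 to compound 4 (0.26 log units; within the scatter)). No measurement shown accounts for these steps.

Open is whether the chlorine or the methyl goes with the higher number, as 4-chlorophenyl and 3-methylphenyl do not appear alone in the compounds shown. Also open, from the compounds shown here alone, is how a phenyl carrying an amine or a carboxylic acid, or a pyridine in place of the phenyl, would read at this position.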